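The source may report more compounds than this note shows. Statements on the series, on what has been measured and on what is new or still open speak of the compounds shown alone.

Measured compounds:
- compound 1 `O=c1c2ccccc2ccn1[C@@H]1O[C@H](COP(=O)(O)OP(=O)(O)OP(=O)(O)O)[C@@H](O)[C@H]1O`: 31 nM
- compound 2 `O=c1c2ccc(F)cc2ccn1[C@@H]1O[C@H](COP(=O)(O)OP(=O)(O)OP(=O)(O)O)[C@@H](O)[C@H]1O`: 77 nM
- compound 3 `O=c1c2ccc(Cl)cc2ccn1[C@@H]1O[C@H](COP(=O)(O)OP(=O)(O)OP(=O)(O)O)[C@@H](O)[C@H]1O`: 541 nM

All three were tested in a functional assay for agonist activity at P2Y purinoceptor 2 (Homo sapiens), read by FLIPR; on this read-out higher numbers stand for an effect only at larger amounts of compound and lower numbers for an effect already at smaller amounts. Compound 1, the parent with a hydrogen at the position in question, has the lowest number of the three; the step of a 2.5-fold higher number from compound 1 to compound 2 (0.40 log units; beyond the scatter) is the nearest, and the step of a 17-fold higher number from compound 1 to compound 3 (1.24 log units; beyond the scatter) the furthest.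

Compound 4 `CS(=O)(=O)c1ccc2ccn([C@@H]3O[C@H](COP(=O)(O)OP(=O)(O)OP(=O)(O)O)[C@@H](O)[C@H]3O)c(=O)c2c1` has not yet been measured in this assay. It differs from compound 1 in one place: methylsulfonyl in place of hydrogen on an aromatic carbon.

The two measured steps that bear on this are the substitutions at the same aromatic carbon. Fluoro gave the step of a 2.5-fold higher number from compound 1 to compound 2 (0.40 log units; beyond the scatter), and chloro gave the step of a 17-fold higher number from compound 1 to compound 3 (1.24 log units; beyond the scatter); the step of a 7.0-fold higher number from compound 2 to compound 3 (0.85 log units; beyond the scatter) shows that the larger substituent went with the higher number. Methylsulfonyl is a larger group than either, so a higher number for compound 4 than for compound 1 is expected in this assay, probably beyond the scatter and of a size at least like that seen for chloro. The estimated step is a 29-fold higher number from compound 1 to compound 4 (1.46 log units; beyond the scatter). Compound 4 is therefore expected to give about 900 nM, within a range of 150 nM to 5000 nM.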

Compound 4, half-maximal effective concentration: 650 nM
Beside the measured number, compound 4's estimate is 1.4-fold (0.14 log units) above it, and the stated range covers the measured number.
By their numbers in this assay, from the lowest: compound 1; then compound 2; then compounds 3 and 4 (each within the scatter of the next).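

In this assay, each of the three groups on this aromatic carbon raises the number, and methylsulfonyl gives a 21-fold higher number from compound 1 to compound 4 (1.32 log units; beyond the scatter). Methylsulfonyl brings 4 heavy atoms, yet compound 3 at 541 nM and compound 4 at 650 nM lie within the usual scatter of each other, so among these compounds the number does not keep climbing as the entering group grows. Nothing shown here explains why these two different groups end up so close.

Still open is how an amine or a carboxylic acid on this carbon would compare with the hydrogen of compound 1, given that all three groups shown raise the number. Also open, on these data alone, is whether methylsulfonyl would give a step of similar size on another carbon of the same ring.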